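A few compounds are considered here, and "the series" means these few. Any claim that something is new, unique, unknown or untested is made for them only; others in the source may bear on it.

Compound 1, `COc1ccc(NC(=O)Nc2nc(Sc3c[nH]c4ccccc34)cc(N3CCN(Cc4ccccc4)CC3)n2)cc1`, gives 8920 nM in a functional assay on MDA-MB-231 cells (Homo sapiens) for inhibition, with a stated time of 72 h; on this read-out lower numbers stand for stronger inhibition and higher numbers for weaker inhibition.
Compound 2, `COc1ccc(NC(=O)Nc2nc(Sc3c[nH]c4ccccc34)cc(N3CCCCC3)n2)cc1`, gives 7260 nM in this assay.
Compound 3, `O=C(Nc1ccc(Cl)cc1)Nc1nc(Sc2c[nH]c3ccccc23)cc(N2CCCC2)n1`, gives 5850 nM in this assay.

Of these three numbers, compound 3 carries the lowest, yet its gaps to compound 2 and to compound 1 both lie within the scatter of repeated measurements, so the three compounds cannot be ranked against one another on this assay. All share the same core, and the three differ in the saturated amine ring and in the substituent on the aryl urea.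

Compound 4, `O=C(Nc1ccccc1)Nc1nc(Sc2c[nH]c3ccccc23)cc(N2CCCC2)n1`, has not yet been measured. It differs from compound 3 in one place: hydrogen in place of chloro on an aromatic carbon. Read one bond further out, a 4-chlorophenyl becomes a phenyl. Going by the values given here, no measured pair among the three compounds shows what such a change does here, so there is no direct guide.

For compound 4 in this assay, a value of 7500 nM is expected, somewhere between 3500 nM and 16000 nM. That estimate means a step of a 1.3-fold higher number from compound 3 to compound 4 (0.11 log units; within the scatter), which is expected to be modest, at the edge of or just beyond the scatter, toward weaker inhibition.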

Compound 4, half-maximal inhibitory concentration: 7890 nM
Compound 4: the middle estimate sits 1.1-fold (0.02 log units) below what was measured; the measured number falls inside the stated range.
By their numbers in this assay, from the lowest: compounds 3, 2, 4 and 1 (each within the scatter of the next).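

Going by these compounds alone, compound 3 and compound 4 form the first pair that differs in one place, and in this assay they give a 1.3-fold higher number from compound 3 to compound 4 (0.13 log units; within the scatter) for hydrogen in place of chloro on the aromatic carbon para to a large group. On this read-out, then, the 4-chlorophenyl and the phenyl cannot be told apart, and the chloro is not shown to matter at this position. No measurement offered here bears on why the pair behaves this way.

A single pair cannot show whether another group at this position, such as a nitrile, a dimethylamino group or a carboxylic acid, would move the number beyond the scatter. On these data alone, what a change of the saturated amine ring does on its own also stays open, as that ring is the same in both compounds.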